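Swapping a pyrimidine for a trifluoromethylphenyl amide

The source may report more compounds than this note shows. Statements on the series, on what has been measured and on what is new or still open speak of the compounds shown alone.

Measured compounds:
Compound 2 `O=C(Nc1ccc(Cl)cc1CN1C(=O)c2ccccc2C1=O)c1ncccn1` gives 2100 nM
Compound 3 `COc1ccc(NC(=O)c2ccccn2)c(CN2C(=O)c3ccccc3C2=O)c1` gives 1400 nM
Compound 1 `COc1ccc2c(c1OC)C(=O)N(Cc1cc(Br)ccc1NC(=O)c1ccccn1)C2=O` gives > 100000 nM

All three were tested in an assay on CHO cells for positive allosteric modulation of metabotropic glutamate receptor 5 (Homo sapiens), read by FLIPR; on this read-out higher numbers stand for an effect only at larger amounts of compound and lower numbers for an effect already at smaller amounts. For compound 1 the result is only a limit of the assay, not a number: the limit of > 100000 nM in this assay, at which 1 of the 3 values shown sits. Compound 2 and compound 3 give numbers that lie within the usual scatter of each other, so neither can be said to act at smaller amounts than the other. Compound 4 `O=C(Nc1ccc(Cl)cc1CN1C(=O)c2ccccc2C1=O)c1ccccc1C(F)(F)F` has not yet been measured. It differs from compound 2 in one place: 2-(trifluoromethyl)phenyl in place of pyrimidin-2-yl on a carbonyl carbon. Going by the values given here, no measured pair shows a change of this kind, so no size of step can be read from the data. As an expectation, a modest weakening a 1.9-fold higher number from compound 2 to compound 4 (0.28 log units; within the scatter) in this assay seems plausible. Compound 4 is therefore estimated at 4000 nM, between 800 nM and 30000 nM.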

Compound 4, half-maximal effective concentration: 5700 nM
For compound 4 the middle estimate is 1.4-fold (0.15 log units) below the measured one; the range from low to high includes it.
By their numbers in this assay, from the lowest: compounds 3 and 2 (each within the scatter of the next); then compound 4. At a limit, above all of these: compound 1.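

At this carbonyl carbon, the ring can change considerably without the effect disappearing: in this assay the swap brings a 2.7-fold higher number from compound 2 to compound 4 (0.43 log units; beyond the scatter) and compound 4 still gives a real number. A pyrimidin-2-yl is therefore not required here for a measurable effect, although the 2-(trifluoromethyl)phenyl comes at a modest cost. No measurement shown bears on why the number rises.

The compounds leave open whether the step follows the departure of the ring nitrogens or the arrival of the trifluoromethyl, since both change together. An unsubstituted phenyl on this carbonyl carbon, which could help separate the two, is not among them.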